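Dithiocarbamate triazole series: both measured compounds at assay limit

The compounds below may be only part of what the source reports. "The series", "measured", "known", "first", "only" and "open" are said of these compounds alone.

In a functional assay on PC-3 cells (Homo sapiens) for inhibition, read by MTT assay, with a stated time of 72 h (on this read-out higher numbers stand for weaker inhibition and lower numbers for stronger inhibition), compound 1 `COc1ccc(Cn2cc(CSC(=S)N3CCN(C(=O)OCc4ccccc4)CC3)nn2)cc1` gives only a limit of the assay, > 128000 nM. Compound 2 `Cc1ccc(-n2cc(CSC(=S)N3CCN(C(=O)OC(C)(C)C)CC3)nn2)cc1` likewise gives only a limit, > 128000 nM. Compound 2 thus stands where every value shown sits, at the limit of > 128000 nM in this assay, at which 2 of the 2 values shown sit. Within the data shown here, compound 3 `COc1ccc(Cn2cc(CSC(=S)N3CCN(C(=O)OC(C)(C)C)CC3)nn2)cc1` differs from compound 2 by 4-methoxybenzyl in place of 4-methylphenyl on an aromatic nitrogen, in words 4-methoxybenzyl in place of 4-methylphenyl on an aromatic nitrogen; no measured step covers this change. Compound 1 already carries this 4-methoxybenzyl group. The expected step is none beyond the scatter, a step that the limit leaves unreadable from compound 2 to compound 3, with a limit again likely. Compound 3 is estimated at 150000 nM, between 60000 nM and 400000 nM.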

Compound 3, half-maximal inhibitory concentration: > 128000 nM
Compound 3 ended at the assay's limit; the forecaster's own chance of this, stated with the estimate: 85%; the middle value lies beyond the limit too.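

No new step can be read, as compound 3 sits at a limit just as compound 1 and compound 2 do: the limit of > 128000 nM in this assay, at which 3 of the 3 values shown sit.

The compounds shown leave open whether exchanging 4-methylphenyl for 4-methoxybenzyl, or benzyl for tert-butyl, changes inhibition at all.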